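The compounds below may be only part of what the source reports. "The series", "measured", "known", "first", "only" and "open" are said of these compounds alone.

Series notes, cytotoxicity on a fibrosarcoma line

Compound 1 `CN1CCN(c2ccc(NC(=N)c3cc4cnn(C)c4cn3)cc2)CC1` carries a methyl on the ring nitrogen of the shared core and an amidine link to a phenyl bearing a methylpiperazine. In a functional assay on HT-1080 cells (Homo sapiens) for cytotoxicity, read by MTT assay, with a stated time of 72 h (on this read-out lower numbers stand for stronger inhibition and higher numbers for weaker inhibition), compound 1 gives 24000 nM. Compound 2 `COc1ccc(Cn2ncc3cc(C(=N)Nc4ccc(N5CCN(C)CC5)cc4)ncc32)cc1` differs from compound 1 by 4-methoxyphenyl in place of hydrogen on a saturated chain carbon bound to an aromatic nitrogen. In this assay compound 2 gives 5300 nM, so the change produced a 4.5-fold lower number from compound 1 to compound 2 (0.66 log units; beyond the scatter).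

Compound 3 `Cn1ncc2cc(C(=N)Nc3cccc(C(F)(F)F)c3)ncc21` keeps the methyl on the core nitrogen but replaces the methylpiperazinyl-phenyl with a trifluoromethyl-substituted phenyl; the difference between the cores of compound 1 and compound 3 is not broken down here. In this assay compound 3 gives 33800 nM, a number that lies within the scatter of the value of compound 1.

Compound 4 `COc1ccc(Cn2ncc3cc(C(=N)Nc4cccc(C(F)(F)F)c4)ncc32)cc1` is not yet measured. Among the measured compounds shown here, it differs from compound 3 by 4-methoxyphenyl in place of hydrogen on a saturated chain carbon bound to an aromatic nitrogen, the same change as the one from compound 1 to compound 2, made at the same place. For the measured compounds named here, only this one pair supplies a precedent, and that pair sits on a different amidine-side phenyl, so the transfer is uncertain. The expectation is that the change acts in the same direction and to a similar extent, resting on the step of a 4.5-fold lower number from compound 1 to compound 2 (0.66 log units; beyond the scatter) seen between compound 1 and compound 2; for compound 4 the expected step is a 4.2-fold lower number from compound 3 to compound 4 (0.63 log units; beyond the scatter). In this assay compound 4 is therefore estimated at 8000 nM, with a likely range from 3000 nM to 22000 nM.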

Compound 4, half-maximal inhibitory concentration: 24900 nM
Beside the measured number, compound 4's estimate is 3.1-fold (0.49 log units) below it; the measured number lies above the stated range.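

Working notes on the transfer: in this assay the new step reads a 1.4-fold lower number from compound 3 to compound 4 (0.13 log units; within the scatter), so on this core the 4-methoxyphenyl change leaves the number within the scatter, and the clear step seen with the methylpiperazinyl-phenyl is not repeated with the trifluoromethyl-substituted phenyl. Among the compounds shown here, the two steps do not agree in size: the same change on two cores in this assay, a 4.5-fold lower number (0.66 log units; beyond the scatter) from compound 1 to compound 2 and a 1.4-fold lower number (0.13 log units; within the scatter) from compound 3 to compound 4, 3.3-fold (0.52 log units) apart, beyond the scatter of two such steps This shows that, in this series, the effect of the change cannot be carried unaltered from one core to another, and that the step depends on what else the compound carries; it does not show which feature of the amidine-side phenyl sets the difference, since only one pair stands on each side and no pair separates the features of the two phenyls.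

Still open, on these data alone, is whether the step on a further amidine-side phenyl, for instance one carrying a morpholine or a carboxylic acid in place of the methylpiperazine or the trifluoromethyl, would follow the larger step or the smaller one. Also open, as far as these compounds go, is whether an unsubstituted benzyl or a longer alkyl chain at the same place would behave as the 4-methoxybenzyl does on either core.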